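From Methoxy to Methyl on the Shared Core

The source may report more compounds than this note shows. Statements on the series, on what has been measured and on what is new or still open speak of the compounds shown alone.

In a functional assay on HL-60 cells (Homo sapiens) for cytotoxicity, read by WST assay, with a stated time of 48 h (on this read-out higher numbers stand for an effect only at larger amounts of compound and lower numbers for an effect already at smaller amounts), compound 1 (`Oc1cccc(C[C@H]2COC[C@@H]2Cc2ccc(Cl)c(Cl)c2)c1`) gives 31000 nM, while compound 2 (`COc1cccc(C[C@H]2COC[C@@H]2Cc2ccc(Cl)c(Cl)c2)c1`) gives 73000 nM, the higher of the two numbers. Compound 3 (`Cc1cccc(C[C@H]2COC[C@@H]2Cc2ccc(Cl)c(Cl)c2)c1`) carries methyl in place of methoxy on an aromatic carbon, meta to a large group (methyl in place of methoxy on an aromatic carbon). Going by the values given here, the only measured step bearing on this change is a 2.4-fold higher number from compound 1 to compound 2 (0.37 log units; beyond the scatter), a modest one. Given that size, no step beyond the scatter is expected in this assay, and the slight direction expected is downward. The expected step is a 1.2-fold lower number from compound 2 to compound 3 (0.09 log units; within the scatter). Compound 3 is estimated at 60000 nM, within a range of 25000 nM to 130000 nM.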

Compound 3, half-maximal effective concentration: 28000 nM
Estimate against measurement, compound 3: 2.1-fold (0.33 log units) above, within the range that was stated.
By their numbers in this assay, from the lowest: compounds 3 and 1 (each within the scatter of the next); then compound 2.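

The change from methoxy to methyl gives a 2.6-fold lower number from compound 2 to compound 3 (0.42 log units; beyond the scatter) in this assay and so shows that the step seen earlier at this aromatic carbon can be undone by a group other than hydroxy. Methyl in place of hydroxy gives a 1.1-fold lower number from compound 1 to compound 3 (0.04 log units; within the scatter) and so these two groups cannot be told apart here, leaving methoxy as the only one of the three that stands out. Nothing measured here gives a reason for this. Going by these compounds, whether an amine, a carboxylic acid or a longer chain at this aromatic carbon would stand with methoxy or with hydroxy and methyl stays open.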